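The source may hold more compounds than are shown below. What is called first, only, known or untested is meant among the compounds shown, and "the series" means these compounds.

Three compounds share one core and differ at one ring. Compound 1 `CN1CCC[C@H]1COc1cccnc1[N+](=O)[O-]` gives 9000 nM in an assay on membranes from brain for displacement of a labelled ligand from Neuronal acetylcholine receptor; alpha4/beta2 (Rattus norvegicus); a lower number here means a stronger inhibitor, a higher number a weaker inhibitor. Compound 2 `CN1CCC[C@H]1COc1cnccc1Br` gives 28 nM in this assay. Compound 3 `CN1CCC[C@H]1COc1ccc(F)nc1` gives 2.56 nM in this assay, the lowest of the three numbers; its separation from compound 2 and from compound 1 lies beyond the scatter, so compound 3 is the strongest binder among them. Compound 4 `CN1CCC[C@H]1COc1ccc(Cl)nc1` has not yet been measured. It differs from compound 3 by chloro in place of fluoro on an aromatic carbon. No measured pair of this kind exists among these compounds, so the step is expected to be small, likely within the scatter. Compound 4 is therefore estimated at 3 nM, with a range of 1 nM to 10 nM in this assay. The expected step is a 1.2-fold higher number from compound 3 to compound 4 (0.07 log units; within the scatter).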

Compound 4, inhibition constant: 0.64 nM
Compound 4: the middle estimate sits 4.7-fold (0.67 log units) above what was measured; measured number below the stated range.
By their numbers in this assay, from the lowest: compound 4; then compound 3; then compound 2; then compound 1.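

In this assay, chloro in place of fluoro on an aromatic carbon next to the ring nitrogen gives a 4.0-fold lower number from compound 3 to compound 4 (0.60 log units; beyond the scatter) and so provides the first measured step among these compounds. It shows that exchanging one halogen for another at this position, a change of a single heavy atom, moves the number beyond the usual scatter. Nothing available here explains why chloro gives the lower number.

Going by these compounds, how a methyl group, an amine or a nitrile at this same position would compare remains open. So does whether chloro would give a similar step on a different core.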